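Fluoro to Methoxybenzyl: What to Expect for Compound 4

A few compounds are considered here, and "the series" means these few. Any claim that something is new, unique, unknown or untested is made for them only; others in the source may bear on it.

Measured in a functional assay on PC-3 cells (Homo sapiens) for inhibition, read by MTT assay, with a stated time of 48 h; a higher number here means a weaker inhibitor, a lower number a stronger inhibitor:
Compound 1 `COc1cc(Cn2cc(COc3cccc(/C=C4/C(=O)Nc5ccccc54)c3)nn2)cc(OC)c1`: 37100 nM
Compound 2 `O=C1Nc2cc(Br)ccc2/C1=C\c1cccc(OCc2cn(Cc3ccccc3)nn2)c1`: > 50000 nM
Compound 3 `O=C1Nc2ccc(F)cc2/C1=C\c1cccc(OCc2cn(Cc3ccccc3)nn2)c1`: > 50000 nM

Compound 3 gives only a limit of this assay, not a number. It shares that position with one other compound: the limit of > 50000 nM in this assay, at which 2 of the 3 values shown sit. Compound 1 alone yields a measured value, and a weak one.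

Compound 4 `COc1ccc(Cc2ccc3c(c2)/C(=C\c2cccc(OCc4cn(Cc5ccccc5)nn4)c2)C(=O)N3)cc1` has not yet been measured. It differs from compound 3 by 4-methoxybenzyl in place of fluoro on an aromatic carbon. No measured step connects the compounds shown, so the direction rests on thin ground. Because compound 1 gives 37100 nM while carrying methoxy groups, compound 4 is expected to remain a weak inhibitor. Compound 4 is expected to give 40000 nM, between 15000 nM and 100000 nM. The step of an at least 1.2-fold lower number from compound 3 to compound 4 (0.09 log units; that floor lies within the scatter) is expected to be small, within the scatter or slightly toward stronger inhibition.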

Compound 4, half-maximal inhibitory concentration: 32200 nM
Estimate against measurement, compound 4: 1.2-fold (0.09 log units) above, within the range that was stated.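

In this assay, among the compounds shown here, 4-methoxybenzyl in place of fluoro on this aromatic carbon gives the only step that can be read: an at least 1.5-fold lower number from compound 3 to compound 4 (0.19 log units; that floor lies within the scatter). That step is only a floor, as compound 3 stands at a limit of the assay, not a number: the limit of > 50000 nM in this assay, at which 2 of the 4 values shown sit. The position thus carries a group with a ring instead of a single atom and compound 4 has a measured value, but no gain in inhibition beyond the scatter is shown.

Going by these compounds, how large the true step is stays open. Also open, on these data alone, is whether an amine or a carboxylic acid in place of 4-methoxybenzyl on this carbon would give a step beyond the scatter.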